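The compounds below may be only part of what the source reports. "The series", "measured", "known", "first", "only" and "open" are said of these compounds alone.

In a physicochemical assay for solubility, in phosphate buffer, measured as kinetic solubility, with a stated time of 1 h, at pH 7.4 (a higher number here means a more soluble compound, a lower number a less soluble compound), the measured compounds are:
- compound 1 `CCNC(=O)Nc1ccc(-c2nccc([C@@]34CCOC[C@@H]3C4)n2)cc1`: 127 ug/mL
- compound 2 `CCNC(=O)Nc1ccc(-c2nc(CS(C)(=O)=O)cc([C@@]34CCOC[C@@H]3C4)n2)cc1`: 77 ug/mL

Compound 1 has a single measured neighbour, and the two numbers cannot be told apart: the step is a 1.6-fold lower number from compound 1 to compound 2 (0.22 log units; within the scatter). Compound 3 `CCNC(=O)Nc1ccc(-c2nccc(C3=CCOCC3)n2)cc1` carries a different change: a group of 6 heavy atoms (5 carbon, 1 oxygen; one six-membered non-aromatic ring with 1 hetero atom) in place of a group of 7 heavy atoms (6 carbon, 1 oxygen; one three-membered non-aromatic ring of carbon only, one six-membered non-aromatic ring with 1 hetero atom), on an aromatic carbon. Among the compounds with values here, the measured step put (methylsulfonyl)methyl in place of hydrogen on an aromatic carbon, so it bears only loosely on this swap, and no measured step touches the group that leaves. A step beyond the scatter in this assay is therefore not expected. The estimated step is a 1.6-fold lower number from compound 1 to compound 3 (0.20 log units; within the scatter). The expected value for compound 3 is 80 ug/mL, with an estimated range of 25 ug/mL to 170 ug/mL.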

Compound 3, solubility: 24 ug/mL
For compound 3 the middle estimate is 3.3-fold (0.52 log units) above the measured one, and the stated range ends above it.
By their numbers in this assay, from the lowest: compound 3; then compounds 2 and 1 (each within the scatter of the next).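

Unlike the (methylsulfonyl)methyl step, the change at the aromatic carbon next to the ring nitrogen moves the number beyond the scatter in this assay. Exchanging the group with the three-membered ring for the six-membered ring with one double bond gives a 5.3-fold lower number from compound 1 to compound 3 (0.72 log units; beyond the scatter), so this position responds to what sits on it. Nothing measured here accounts for the difference. The compounds shown do not separate losing the three-membered ring from gaining the double bond. A saturated six-membered ring with one oxygen at this position would be needed to tell those two apart.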